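A few compounds are considered here, and "the series" means these few. Any claim that something is new, unique, unknown or untested is made for them only; others in the source may bear on it.

Compound 1, `CCCCCCc1nc2ccccc2[nH]1`, gives 3.93 in a physicochemical assay for lipophilicity; a lower number here means a more polar compound, a higher number a more lipophilic compound.
Compound 2, `CCCCCCCc1nc2ccccc2[nH]1`, gives 4.43 in this assay.
Compound 3, `Cc1ccc2[nH]c(C)nc2c1`, gives 1.94 in this assay.

Compound 3 thus gives the lowest of the three numbers, and the gaps to compound 1 and compound 2 both lie beyond the scatter. Between compound 1 and compound 2 the change is methyl in place of hydrogen on a saturated chain carbon, six bonds along the chain from an aromatic carbon, and it produced a number 0.50 log units higher from compound 1 to compound 2 (beyond the scatter). Compound 4, `CCc1nc2cc(C)ccc2[nH]1`, is not yet measured; it arises from compound 3 by methyl in place of hydrogen on a saturated chain carbon bound to an aromatic carbon. This is the same kind of change, but the place differs: in compound 2 the methyl sits six bonds along the chain from an aromatic carbon, in compound 4 on a saturated chain carbon bound to an aromatic carbon. How the core of compound 1 and the core of compound 3 differ is not broken down here. For compound 4 a step of about a number 0.50 log units higher from compound 3 to compound 4 (beyond the scatter) is expected in this assay, resting on a number 0.50 log units higher from compound 1 to compound 2 (beyond the scatter). Compound 4 is therefore estimated at 2.44, between 2.1 and 2.8.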

Compound 4, partition coefficient: 2.44
Compound 4: the middle estimate sits on the measured number at the digits printed, and the stated range covers the measured number.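

In this assay, methyl in place of hydrogen on a saturated chain carbon bound to an aromatic carbon gave a number 0.50 log units higher from compound 3 to compound 4 (beyond the scatter), a step of the same printed size as a number 0.50 log units higher from compound 1 to compound 2 (beyond the scatter). This shows that the same kind of change carried over from one core to another in these two pairs, but the core and the place on the chain differ together, so two pairs cannot separate their contributions or establish a rule for other cores. Nothing measured here explains why the two steps agree.

Going by these compounds, it remains open whether methyl to ethyl would be followed by a similar step on a longer chain at this place. On these data alone, it is also open how an amine or a carboxylic acid in place of the methyl would shift the number.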